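Amide swap on the shared piperidine series

A few compounds are considered here, and "the series" means these few. Any claim that something is new, unique, unknown or untested is made for them only; others in the source may bear on it.

Compound 1 `CCCC(NC(=O)c1ccccc1C)C(=O)N1CCC(c2ccc(Cl)cc2)CC1`: 152 nM
Compound 2 `CC(C)C(=O)NC(C(=O)N1CCC(c2ccc(Cl)cc2)CC1)C(C)C`: 388 nM

In an assay on THP-1 cells for displacement of a labelled ligand from C-C chemokine receptor type 1 (Homo sapiens) (on this read-out lower numbers stand for stronger inhibition and higher numbers for weaker inhibition), compound 1 gives 152 nM, and compound 2 gives 388 nM, the highest of the two numbers and separated from compound 1 by a gap beyond the scatter. Compound 3 `Cc1ccccc1C(=O)NC(C(=O)N1CCC(c2ccc(Cl)cc2)CC1)C(C)C` has not been measured. It arises from compound 2 by 2-methylphenyl in place of isopropyl on a carbonyl carbon, the same amide found in compound 1. Since the acyl group of compound 1 goes with the lower number, the step from compound 2 to compound 3 is expected to lower the number, by about a 2.2-fold lower number from compound 2 to compound 3 (0.33 log units; beyond the scatter), beyond the scatter. Compound 3 is estimated at 180 nM, within 80 nM to 400 nM.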

Compound 3, half-maximal inhibitory concentration: 36 nM
For compound 3 the middle estimate is 5.0-fold (0.70 log units) above the measured one, outside the stated range (below it).
By their numbers in this assay, from the lowest: compound 3; then compound 1; then compound 2.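

In this assay, 2-methylphenyl in place of isopropyl on a carbonyl carbon gives an 11-fold lower number from compound 2 to compound 3 (1.03 log units; beyond the scatter) and shows that this acyl position responds strongly when the side chain carries isopropyl. With the 2-methylphenyl amide held fixed, isopropyl in place of propyl on a saturated chain carbon bound to an amide-type nitrogen and a carbonyl carbon gives a 4.2-fold lower number from compound 1 to compound 3 (0.63 log units; beyond the scatter) and shows that the side chain also moves the number. Nothing here accounts for either step. The compounds shown do not separate the aromatic ring from its methyl, which an unsubstituted phenyl would test. From the compounds shown here alone, how an amine or a carboxylic acid on that ring would read also remains open.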